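Sulfonamide series: ester in place of amide

The compounds below may be only part of what the source reports. "The series", "measured", "known", "first", "only" and "open" are said of these compounds alone.

The study concerns inhibitors measured in an assay on isolated protein for inhibition of alkaline phosphatase, tissue-nonspecific isozyme (Homo sapiens); a higher number here means a weaker inhibitor, a lower number a stronger inhibitor. Of the compounds shown here, two have been measured. Compound 1, `COc1ccc(C(N)=O)cc1S(=O)(=O)Nc1cccnc1`, gives 1490 nM in this assay. Compound 2, `COC(=O)c1cncc(NS(=O)(=O)c2cc(Cl)ccc2OC)c1`, gives 65 nM in this assay. Compound 1 therefore stands at the highest of the two numbers, and its nearest neighbour, compound 2, sits far below it, well beyond the scatter; the two structures differ in more than one place, so nothing more than the two values themselves can be said of that gap.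

Compound 3, `COC(=O)c1ccc(OC)c(S(=O)(=O)Nc2cccnc2)c1`, has not yet been measured. It differs from compound 1 by the change (methoxy in place of amino on a carbonyl carbon), that is, methoxy in place of amino on a carbonyl carbon whose other neighbours are aromatic carbon, or, cut one bond further out, carbamoyl to methoxycarbonyl. Among the compounds with values here, no measured pair shows this change on its own, so the expectation rests on compound 1 alone. A modest step downwards is expected, a 2.5-fold lower number from compound 1 to compound 3 (0.40 log units; beyond the scatter), somewhat larger than the scatter but far short of the distance to compound 2. Compound 3 is accordingly estimated at 600 nM in this assay, within a range from 200 nM to 2500 nM.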

Compound 3, half-maximal inhibitory concentration: 1510 nM
Compound 3: middle estimate off by 2.5-fold (0.40 log units), on the low side, and the stated range covers the measured number.
By their numbers in this assay, from the lowest: compound 2; then compounds 1 and 3 (each within the scatter of the next).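

In this assay, within the data shown here, methoxy in place of amino on a carbonyl carbon gives a 1.0-fold higher number from compound 1 to compound 3 (0.01 log units; within the scatter), the first step in this set that isolates a single change. On the core of compound 1, the carbamoyl to methoxycarbonyl swap takes away the amino group with its hydrogen-bond donor and brings in methoxy with its hydrogen-bond acceptor and one more heavy atom, yet the two compounds cannot be told apart in this assay. No measurement of any property of these compounds bears on this result.

Still open, on these data alone, is whether other groups on the same carbonyl carbon, such as a carboxylic acid, an ethyl ester or an N-methyl amide, would also stay within the scatter of compound 1, or whether any of them would separate from it. Compound 2 differs from compound 1 and compound 3 in more than one place, so the number for compound 2 of 65 nM cannot be tied to any single group, and the same swap on a core like that of compound 2 remains untested in what is shown here.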